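Adding a Phenyl Ring to a Thiosemicarbazide Arm

The compounds below may be only part of what the source reports. "The series", "measured", "known", "first", "only" and "open" are said of these compounds alone.

Of the compounds shown here, three sharing a common core have been measured in a functional assay on K562 cells (Homo sapiens) for antiproliferative activity, read by sulforhodamine B assay, with a stated time of 72 h; a higher number here means a weaker inhibitor, a lower number a stronger inhibitor. Compound 1 `Cc1ccc(C(/C=C/c2ccc(F)cc2)=N\Nc2nncc3ccccc23)cc1` gives 5 nM. Compound 2 `NC(=S)NNc1nncc2ccccc12` gives 23 nM, and compound 3 `O=S(=O)(Nc1ncccn1)c1ccc(Nc2nncc3ccccc23)cc1` gives 43 nM. Compound 2 thus has the second highest of the three numbers; its number sits within the usual scatter of that of compound 3, so the two cannot be told apart, while the number of compound 1 lies beyond the scatter, below it.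

Compound 4 `S=C(NNc1nncc2ccccc12)Nc1ccccc1` has not yet been measured. It differs from compound 2 in one place: phenyl in place of hydrogen on an amide-type nitrogen. Nothing in the measured set shows how this particular change plays out, so the expectation rests on the spread of the three numbers alone. Compound 4 is expected to land close to compound 2, with any difference likely staying near the edge of the scatter, most plausibly toward a lower number. Accordingly, compound 4 is estimated at 15 nM, with a range from 4 nM to 60 nM. The expected step is a 1.5-fold lower number from compound 2 to compound 4 (0.19 log units; within the scatter).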

Compound 4, half-maximal inhibitory concentration: 76 nM
Compound 4: the middle estimate sits 5.1-fold (0.70 log units) below what was measured; the measured number lies above the stated range.
By their numbers in this assay, from the lowest: compound 1; then compounds 2, 3 and 4 (each within the scatter of the next, the first and the last beyond it).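

In this assay, going by these compounds alone, the change from amino to anilino gives a 3.3-fold higher number from compound 2 to compound 4 (0.52 log units; beyond the scatter) and this modest step is the first direct reading of a single change, since the earlier compounds formed no pair differing in one place. It shows that the amide-type nitrogen on the thiocarbonyl carbon is not indifferent to what it carries: here, phenyl in place of hydrogen weakens the antiproliferative effect. Nothing available explains this loss.

From the compounds shown here alone, it remains open whether methyl or benzyl on this nitrogen would give a number closer to that of compound 2 or further from it. Also open, going by these compounds, is whether a fluoro or methoxy group on the phenyl ring of compound 4 would recover any activity.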